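The source may report more compounds than this note shows. Statements on the series, on what has been measured and on what is new or still open speak of the compounds shown alone.

This piece follows one change made to compound 3 `COc1cc(-c2nn(-c3cccc(NC(=O)Nc4ccc(Cl)c(C(F)(F)F)c4)c3)cc2-c2ccncc2)ccc1Cl`. In a functional assay on UACC-62 cells (Homo sapiens) for inhibition, read by sulforhodamine B assay, with a stated time of 48 h (on this read-out lower numbers stand for stronger inhibition of growth and higher numbers for weaker inhibition of growth), compound 3 gives 2090 nM. Compound 1 `COc1cc(-c2nn(-c3cccc(NC(=O)Nc4ccc(Cl)c(Cl)c4)c3)cc2-c2ccncc2)ccc1Cl` carries chloro where compound 3 carries trifluoromethyl. In this assay compound 1 gives 1860 nM, and the step is a 1.1-fold higher number from compound 1 to compound 3 (0.05 log units; within the scatter). Compound 2 `COc1cc(-c2nn(-c3cccc(NC(=O)c4ccc(Cl)c(C(F)(F)F)c4)c3)cc2-c2ccncc2)ccc1Cl` is a different case: in this assay compound 2 reaches only a limit, > 32500 nM. Compound 3 thus has the highest of the two plain numbers, with compound 1 nearest.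

The unmeasured compound 4 `COc1cc(-c2nn(-c3cccc(NC(=O)c4ccccc4)c3)cc2-c2ccncc2)ccc1Cl` differs from compound 3 in one place: phenyl in place of (4-chloro-3-(trifluoromethyl)phenyl)amino on a carbonyl carbon. Two of the measured steps bear on this change: an at least 17-fold higher number from compound 1 to compound 2 (1.24 log units; beyond the scatter), and an at least 15-fold lower number from compound 2 to compound 3 (1.19 log units; beyond the scatter). Both show that a ring attached directly to the carbonyl carbon, instead of through an amino link, weakens growth inhibition strongly, with the weaker compound reaching (the limit of > 32500 nM in this assay, at which 1 of the 3 values shown sits). Compound 4 makes the same kind of change and also drops the chloro and trifluoromethyl groups, for which compound 1 and compound 3 give no separate guidance. Compound 4 is therefore expected to show a large step up, a 14-fold higher number from compound 3 to compound 4 (1.16 log units; beyond the scatter), quite possibly reaching the limit of this assay. The estimated value for compound 4 is 30000 nM, within a range from 8000 nM to 100000 nM.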

Compound 4, concentration for total growth inhibition: > 100000 nM
Compound 4 ended at the assay's limit; the forecaster's own chance of this, stated with the estimate: 60%; at least 3.3-fold (0.52 log units) between middle value and limit.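

Replacing the (4-chloro-3-(trifluoromethyl)phenyl)amino group with a bare phenyl on the carbonyl carbon sharply weakens growth inhibition in this assay: the result is an at least 47-fold higher number from compound 3 to compound 4 (1.67 log units; beyond the scatter), and the comparison with the dichloro analogue gives an at least 53-fold higher number from compound 1 to compound 4 (1.73 log units; beyond the scatter). Compound 4 gives only a limit, not a plain number, and like compound 2 it has a ring attached directly to the carbonyl carbon without an amino link: the limit of > 100000 nM in this assay, at which 1 of the 4 values shown sits. Compound 2 and compound 4 both stop at limits, so the step between them cannot be read, and the compounds give no measure of what the chloro and trifluoromethyl groups contribute once the amino link is gone.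

The compounds shown leave open whether a plain phenylamino group, with the amino link kept but no chloro or trifluoromethyl on the ring, would retain growth inhibition, a comparison that would help separate the role of the link from that of the ring substituents. Also open, going by these compounds, is how this assay would read for a methylene link in place of the amino link, or for a methoxy group or a carboxylic acid on the ring.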